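The source may report more compounds than this note shows. Statements on the series, on what has been measured and on what is new or still open speak of the compounds shown alone.

Measured so far in an assay on HEK293 cells for displacement of a labelled ligand from Neuronal acetylcholine receptor; alpha4/beta2 (Homo sapiens); on this read-out higher numbers stand for weaker inhibition and lower numbers for stronger inhibition:

- compound 1, `c1ccc2ncc(N3CCCNCC3)cc2c1`: 6.61 nM
- compound 2, `COc1cc(N2CCNCC2)cnc1Br`: 182 nM
- compound 3, `Oc1cc(N2CCCNCC2)cnc1I`: 21.9 nM

Three compounds carry a number in this assay. Compound 1 gives 6.61 nM, compound 3 gives 21.9 nM, and compound 2 gives 182 nM, the highest of the three and beyond the scatter from both of the others. No pair among these three differs in one place only, so the three numbers are read side by side and not as steps.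

The next compound, compound 4, `Brc1ccc(N2CCNCC2)cn1`, is not yet measured in this assay. It is made from compound 2 by one change: hydrogen in place of methoxy on an aromatic carbon. Nothing in the measured set shows what the loss of a methoxy group does here, and compound 1 and compound 3 differ from compound 2 in more than one place, so they carry no direct weight for this step.

Within the data shown here, with no step of this kind on record, the working expectation is a step of no more than moderate size, if any, in either direction; the number expected for compound 4 is 120 nM, within 30 nM to 500 nM, which means an expected step of a 1.5-fold lower number from compound 2 to compound 4 (0.18 log units; within the scatter) that may well fall inside the scatter.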

Compound 4, half-maximal inhibitory concentration: 182 nM
For compound 4 the middle estimate is 1.5-fold (0.18 log units) below the measured one; the range from low to high includes it.
By their numbers in this assay, from the lowest: compound 1; then compound 3; then compounds 2 and 4 (each within the scatter of the next).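

In this assay, among these compounds, the step of no change at the digits printed from compound 2 to compound 4 (within the scatter) is the first comparison that differs in one place only, and it concerns hydrogen in place of methoxy on an aromatic carbon ortho to a bromo group. For this pair, the methoxy group and its 2 heavy atoms can leave that carbon without a step beyond the scatter, so the read-out does not separate the two groups at this place. Nothing on record bears on the reason for this flat step.

Among the compounds shown here, open in this assay is what an amine, a carboxylic acid or a longer alkoxy chain such as ethoxy would do on that same carbon, as hydrogen and methoxy are the only two groups compared there. Also open, as far as these compounds go, is whether the flat step carries over to other cores, as the reading rests on a single pair and neither compound 1 nor compound 3 differs from compound 2 or compound 4 in one place only.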